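A sec-butyl swap on compound 2

The source may report more compounds than this note shows. Statements on the series, on what has been measured and on what is new or still open speak of the compounds shown alone.

In a functional assay on the whole organism with Scenedesmus acutus as the target (a lower number here means a stronger inhibitor, a higher number a weaker inhibitor), compound 1 `CC(C)OC(=O)c1cc(N2C(=O)C3=C(CCCC3)C2=O)c(F)cc1Cl` gives 57.5 nM and compound 2 `CC(C)COC(=O)c1cc(N2C(=O)C3=C(CCCC3)C2=O)c(F)cc1Cl` gives 33.1 nM. Repeat measurements of one compound also differ somewhat, and this scatter sets how large a gap must be to count as real. Among the compounds with values here, the only measured step is a 1.7-fold lower number from compound 1 to compound 2 (0.24 log units; within the scatter), so compound 2 stands level with its single neighbour. Compound 3 `CCC(C)OC(=O)c1cc(N2C(=O)C3=C(CCCC3)C2=O)c(F)cc1Cl` keeps the shared core and has the same atoms as compound 2, joined differently: sec-butyl in place of isobutyl on an oxygen next to a carbonyl group. Within the data shown here, the one step that bears on this change sits at the same place, and it stayed within the scatter. No clear shift in either direction is therefore expected in this assay, and the estimated change is a 1.3-fold higher number from compound 2 to compound 3 (0.10 log units; within the scatter). Compound 3 is estimated at 42 nM, with an expected range of 18 nM to 95 nM.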

Compound 3, half-maximal inhibitory concentration: 24.6 nM
Beside the measured number, compound 3's estimate is 1.7-fold (0.23 log units) above it, within the range that was stated.
By their numbers in this assay, from the lowest: compounds 3, 2 and 1 (each within the scatter of the next, the first and the last beyond it).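

Swapping isobutyl for sec-butyl on an oxygen next to a carbonyl group rearranges the same four carbons and gives a 1.3-fold lower number from compound 2 to compound 3 (0.13 log units; within the scatter), so in this assay this rearrangement does not separate the two compounds. Within the data shown here, the step from the isopropyl compound is the first at this position to clear the scatter: a 2.3-fold lower number from compound 1 to compound 3 (0.37 log units; beyond the scatter), a modest change that comes with methyl in place of hydrogen on a saturated chain carbon, two bonds along the chain from an oxygen next to a carbonyl group. Nothing available explains this step.

As far as these compounds go, what a longer chain such as pentyl or a ring such as cyclopentyl would do on this oxygen remains open. So does the effect of a carboxylic acid at this place.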